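This account rests on a few compounds, and the source may have more. Where it says the series, first, only, none or still open, it means among the compounds named here.

Measured so far in a functional assay on HeLa cells (Homo sapiens) for cytotoxicity, read by WST assay, with a stated time of 48 h; a higher number here means a weaker inhibitor, a lower number a stronger inhibitor:

- compound 1, `COc1ccc(/C=C/C[C@H]2C[C@H]([C@H](O)c3ccc(OC)c(OC)c3)CO[C@@H]2c2ccc(OC)c(OC)c2)cc1OC`: 34600 nM
- compound 2, `COc1ccc(/C=C/C[C@@H]2C[C@@H]([C@@H](O)c3ccc(OC)c(OC)c3)CO[C@H]2c2ccc(OC)c(OC)c2)cc1`: 17100 nM
- compound 3, `O[C@@H](c1ccccc1)[C@H]1CO[C@H](c2ccccc2)[C@@H](C/C=C/c2cccc(F)c2)C1`: 8380 nM

Compound 3 gives the lowest number of the three in this assay. Its nearest neighbour is compound 2, whose value lies beyond the scatter above it; compound 1 sits further off still. Going by the values given here, no pair of these three differs in only one place, so no single-point step can be read from them.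

The next compound, compound 4, `Cc1ccc(/C=C/C[C@H]2C[C@@H]([C@@H](O)c3ccccc3)CO[C@@H]2c2ccccc2)cc1C`, is compound 3 with one change: 3,4-dimethylphenyl in place of 3-fluorophenyl on a double-bonded chain carbon bound to a double-bonded chain carbon. The group that leaves and the group that enters carry no hydrogen-bond donors or acceptors and no charge, and each is a single six-membered aromatic ring of carbon only. Nothing measured here shows what such an exchange on the double-bonded chain carbon does to the number in this assay.

The step from compound 3 to compound 4 is therefore expected to be small, a 1.0-fold lower number from compound 3 to compound 4 (0.02 log units; within the scatter), in no direction beyond the scatter. Compound 4 is expected at about 8000 nM, in a range from 3000 nM to 25000 nM.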

Compound 4, half-maximal inhibitory concentration: 10000 nM
Beside the measured number, compound 4's estimate is 1.3-fold (0.10 log units) below it; measured number inside the range.
By their numbers in this assay, from the lowest: compounds 3, 4 and 2 (each within the scatter of the next, the first and the last beyond it); then compound 1.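

In this assay, going by these compounds alone, the only single-place step so far is a 1.2-fold higher number from compound 3 to compound 4 (0.08 log units; within the scatter), with 3,4-dimethylphenyl in place of 3-fluorophenyl on a double-bonded chain carbon bound to a double-bonded chain carbon. This shows that, for this pair, exchanging one six-membered aromatic ring of carbon only for another at this place does not move the number beyond the scatter, even with fluorine leaving and only carbon entering. No measurement at hand accounts for this result.

As far as these compounds go, whether an aryl ring carrying an amine or a carboxylic acid at this place, or a longer chain ending in the same ring, would move the number beyond the scatter stays open. Also open, from the compounds shown here alone, is whether the same exchange would read the same way on the core of compound 1.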